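The source may report more compounds than this note shows. Statements on the series, on what has been measured and on what is new or still open speak of the compounds shown alone.

Among the measured compounds shown here, in an ADME assay on L02 cells (Homo sapiens) for cytotoxicity, read by MTT assay, with a stated time of 48 h (a higher number here means a weaker inhibitor, a lower number a stronger inhibitor), compound 2 (`C#CCNC(=O)c1ccc(C(CC)(CC)c2ccc(OCC(O)C(C)(C)C)c(C)c2)n1CC`) gives 4400 nM and compound 1 (`CCN(CC)CCNC(=O)c1ccc(C(CC)(CC)c2ccc(OCC(O)C(C)(C)C)c(C)c2)n1CC`) gives 2500 nM as the only other number, and the two lie within the scatter of each other. Compound 3 (`CCn1c(C(=O)NCC(OC)OC)ccc1C(CC)(CC)c1ccc(OCC(O)C(C)(C)C)c(C)c1`) has dimethoxymethyl in place of ethynyl on a saturated chain carbon bound to an amide-type nitrogen, which turns propargylcarbamoyl into (2,2-dimethoxyethyl)carbamoyl. For the measured compounds named here, only one measured step bears on this place, with ethynyl in place of (diethylamino)methyl. Going by the values given here, with only that step (a 1.8-fold higher number from compound 1 to compound 2 (0.25 log units; within the scatter)) to go on, no step beyond the scatter is expected in this assay in either direction, although no measured compound carries dimethoxymethyl and a single step is thin evidence. The estimated step is small (a 1.1-fold lower number from compound 2 to compound 3 (0.04 log units; within the scatter)). Compound 3 is expected at 4000 nM with an estimated range from 1800 nM to 9000 nM in this measurement.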

Compound 3, half-maximal inhibitory concentration: 22200 nM
For compound 3 the middle estimate is 5.6-fold (0.74 log units) below the measured one; measured number outside the range, above it.
By their numbers in this assay, from the lowest: compounds 1 and 2 (each within the scatter of the next); then compound 3.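

In this assay, among the compounds shown here, this position proves less indifferent than the first pair of compounds suggested: dimethoxymethyl on the saturated chain carbon bound to the amide-type nitrogen gives a 5.0-fold higher number from compound 2 to compound 3 (0.70 log units; beyond the scatter), and, against the amine-bearing chain, an 8.9-fold higher number from compound 1 to compound 3 (0.95 log units; beyond the scatter). A higher number here means a weaker inhibitor, so compound 3 is the weakest of the three, while ethynyl and (diethylamino)methyl remain within the scatter of each other. Nothing in the data at hand explains the rise.

The three compounds leave open whether the change goes with the oxygen atoms of dimethoxymethyl or simply with a larger group on this carbon. A methoxymethyl group or a longer plain alkyl chain at the same place would help separate those two readings, and a carboxylic acid there would widen the comparison.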